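The source may hold more compounds than are shown below. What is called first, only, known or untested is meant among the compounds shown, and "the series" means these compounds.

Compound 1 `Cc1ncc(-c2ccccc2NCC2=NCCN2)o1` in a functional assay for activation of Alpha-1D adrenergic receptor (Homo sapiens) (on this read-out lower numbers stand for an effect already at smaller amounts and higher numbers for an effect only at larger amounts of compound), gives < 5020 nM, which is a limit of the assay and not a number.
Compound 2 `Cc1nc(-c2ccccc2NCC2=NCCN2)cs1` gives < 5020 nM, again only a limit.
Compound 3 `Cc1ccc(-c2ccccc2NCC2=NCCN2)o1` gives < 2000 nM, also a limit rather than a number.

Compound 3 thus stands at the limit of < 2000 nM in this assay, at which 1 of the 3 values shown sits, while the other two compounds sit at the limit of < 5020 nM in this assay, at which 2 of the 3 values shown sit. Every value is a limit. None of the three measured steps can be read: they are a step that the two limits leave unreadable from compound 1 to compound 2, a step that the two limits leave unreadable from compound 1 to compound 3 and a step that the two limits leave unreadable from compound 2 to compound 3. Compound 4 `c1ccc(-c2ccccc2NCC2=NCCN2)nc1` differs from compound 3 in one place: pyridin-2-yl in place of 5-methylfuran-2-yl on an aromatic carbon. All three measured steps swap one small aromatic ring for another at this same place, on an aromatic carbon, so they bear directly on this change; yet each of them is unreadable and gives neither a size nor a direction. What remains is that compound 3 already sits at the tighter of the two limits, and a pyridin-2-yl ring is of the same size as the ring it replaces. The expected step in this assay is therefore a step that the limit leaves unreadable from compound 3 to compound 4, nothing beyond the scatter. Compound 4 is estimated at 1500 nM, within 200 nM to 5020 nM, with a good chance that only a limit is reported again.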

Compound 4, half-maximal effective concentration: 41.7 nM
For compound 4 the middle estimate is 36-fold (1.56 log units) above the measured one; measured number outside the range, below it.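

The steps to compound 4 from compound 1, compound 2 and compound 3 cannot be read: each of those three compounds carries only a limit of the assay, not a number. As far as these compounds go, what stays open is how large the difference between compound 4 and each of the other three compounds is in this assay, and in which direction it runs.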